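Adding a methoxy group to compound 3

The source may report more compounds than this note shows. Statements on the series, on what has been measured and on what is new or still open speak of the compounds shown alone.

Measured in an ADME assay on Vero cells (Chlorocebus sabaeus) for cytotoxicity, read by MTT assay; on this read-out lower numbers stand for stronger inhibition and higher numbers for weaker inhibition:
- compound 1 `C=CCOc1cc(OC)c(C(=O)/C=C/c2ccc(F)cc2)c(OCC=C)c1`: 13600 nM
- compound 2 `C=CCOc1cc(OC)c(C(=O)/C=C/c2ccc(O)cc2)c(OCC=C)c1`: 76400 nM
- compound 3 `C=CCOc1cc(OC)c(C(=O)/C=C/c2ccccc2)c(OCC=C)c1`: 17100 nM

Compound 3 sits level with compound 1, and compound 2 stands apart from both. The numbers show a 1.3-fold higher number from compound 1 to compound 3 (0.10 log units; within the scatter), and they show a 4.5-fold lower number from compound 2 to compound 3 (0.65 log units; beyond the scatter).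

The next molecule, compound 4 `C=CCOc1cc(OC)c(C(=O)/C=C/c2cccc(OC)c2)c(OCC=C)c1`, turns the phenyl into 3-methoxyphenyl: methoxy in place of hydrogen on an aromatic carbon. For the measured compounds named here, no measured step adds a methoxy, so the evidence is indirect. The nearest guides are the other swaps on an aromatic carbon. Hydroxy in place of fluoro gave a 5.6-fold higher number from compound 1 to compound 2 (0.75 log units; beyond the scatter), a real change, while replacing fluoro with hydrogen gave a step within the scatter. These two outcomes do not fix a direction, so a step no larger than the scatter is expected in this assay, perhaps slightly upward. The estimated change is a 1.1-fold higher number from compound 3 to compound 4 (0.05 log units; within the scatter). For compound 4 the expected value is 19000 nM, with an estimated range from 8000 nM to 45000 nM.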

Compound 4, half-maximal inhibitory concentration: 142000 nM
Compound 4: middle estimate off by 7.5-fold (0.87 log units), on the low side, and the stated range ends below it.
By their numbers in this assay, from the lowest: compounds 1 and 3 (each within the scatter of the next); then compounds 2 and 4 (each within the scatter of the next).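

In this assay, adding a methoxy at this spot on the aromatic ring, meta to a large group, is far from a neutral change: it gives an 8.3-fold higher number from compound 3 to compound 4 (0.92 log units; beyond the scatter) and so moves the number well beyond the scatter. Set against the fluoro compound, the same 3-methoxyphenyl group gives a 10-fold higher number from compound 1 to compound 4 (1.02 log units; beyond the scatter) and the largest step in this set, while a 1.9-fold higher number from compound 2 to compound 4 (0.27 log units; within the scatter) stays within the scatter, which places compound 4 level with the hydroxy compound. Nothing measured here bears on why so small a group shifts the number this far.

Going by these compounds, what remains open is whether this jump belongs to the methoxy group itself or to its place on the ring. An amine or a longer chain such as ethoxy at the same carbon could show whether other groups there move the number as far.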